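The compounds below may be only part of what the source reports. "The series", "measured", "known", "first", "only" and "open" are said of these compounds alone.

Compound 1, `CC1(C)O[C@H]2O[C@H](Cn3cc(CN4C(=O)/C(=N\Nc5ccccc5)c5ccccc54)nn3)[C@H](O)[C@H]2O1`: 82100 nM
Compound 2, `O=C1/C(=N\Nc2ccccc2)c2ccccc2N1Cc1cn(O[C@@H]2O[C@H](CO)[C@@H](O)[C@H](O)[C@H]2O)nn1`: 88500 nM

In an ADME assay on Vero cells (Chlorocebus sabaeus) for cytotoxicity, read by fluorescence and resazurin assay, with a stated time of 3 days (on this read-out higher numbers stand for lower toxicity in this test and lower numbers for higher toxicity in this test), compound 2 shows the higher of the two numbers, with compound 1 the nearest, but the step of a 1.1-fold higher number from compound 1 to compound 2 (0.03 log units; within the scatter) lies within the scatter, so the two compounds cannot be told apart on this read-out despite the exchange of one group for another on the aromatic nitrogen. Compound 3, `O=C1/C(=N\Nc2ccccc2)c2ccccc2N1Cc1cn(O[C@@H]2O[C@H](CO)[C@H](O)[C@H](O)[C@H]2O)nn1`, keeps every atom and bond of compound 2: the two compounds have the same atoms and bonds and differ only in configuration as drawn: 1 of 6 stereo elements differ; a stereocentre at a saturated ring carbon is drawn S in compound 2 and R in compound 3. For the measured compounds named here, none of the measured steps changes a configuration, so the only guide is the step from compound 1 to compound 2, which was small for a far larger change. Compound 3 is therefore expected to land near compound 2, with a 1.0-fold lower number from compound 2 to compound 3 (0.00 log units; within the scatter) not beyond the scatter. For compound 3 the estimate in this assay is 88000 nM, ranging from 45000 nM to 175000 nM.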

Compound 3, half-maximal cytotoxic concentration: 83400 nM
The estimate for compound 3 lay 1.1-fold (0.02 log units) above the measured number; low and high end bracket the measured number.
By their numbers in this assay, from the lowest: compounds 1, 3 and 2 (each within the scatter of the next).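

In this assay, for the compounds shown here, the new result gives the first look at a change of configuration alone, and inverting this one stereocentre at a saturated ring carbon comes out as a 1.1-fold lower number from compound 2 to compound 3 (0.03 log units; within the scatter). The exchange of groups on the aromatic nitrogen, read with the new configuration, gives a 1.0-fold higher number from compound 1 to compound 3 (0.01 log units; within the scatter), so that exchange cannot be told apart on this read-out with either drawing of the six-membered ring. This pair is a clean test of that single centre: the fact that compounds 2 and 3 differ only in the configuration as drawn.

The compounds shown leave open whether inverting the other stereocentres of this ring would also go unseen in this test. They also leave open what an amine, a carboxylic acid or a plain butyl chain would give on the aromatic nitrogen in place of these ring groups.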